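Demethylation step in a pyrazole urea series lacking measurable potency

The source may hold more compounds than are shown below. What is called first, only, known or untested is meant among the compounds shown, and "the series" means these compounds.

Measured so far:
compound 1 `O=C(Nc1cccc(-n2cc(-c3ccncc3)c(-c3ccc(Cl)c(O)c3)n2)c1)Nc1cccc(C(F)(F)F)c1` — > 32500 nM
compound 2 `COc1cc(-c2nn(-c3cccc(NC(=O)Nc4cc(C(F)(F)F)cc(C(F)(F)F)c4)c3)cc2-c2ccncc2)ccc1Cl` — > 50000 nM

In a functional assay on OVCAR-8 cells (Homo sapiens) for inhibition, read by sulforhodamine B assay, with a stated time of 48 h (a higher number here means that more compound is tolerated, a lower number that less compound is tolerated), compound 2 reaches only a limit, > 50000 nM. Compound 1 also reaches only a limit in this assay, > 32500 nM. Going by the values given here, no step between measured compounds is available; both values sit at limits the limit of > 32500 nM in this assay, at which 1 of the 2 values shown sits (the limit of > 50000 nM in this assay, at which 1 of the 2 values shown sits).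

Compound 3 `O=C(Nc1cccc(-n2cc(-c3ccncc3)c(-c3ccc(Cl)c(O)c3)n2)c1)Nc1cc(C(F)(F)F)cc(C(F)(F)F)c1` differs from compound 2 by hydrogen in place of methyl on an oxygen on an aromatic ring. Compound 1 already carries the hydroxy group and gives a limit, so no shift beyond scatter is expected; compound 3 is estimated at 50000 nM (range 20000 nM to 120000 nM), a step of a number no higher from compound 2 to compound 3 (the limit leaves the size open).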

Compound 3, concentration lethal to 50% of the cells: 43700 nM
Compound 3: middle estimate off by 1.1-fold (0.06 log units), on the high side; the range from low to high includes it.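

In this assay, going by these compounds alone, compound 3 gives 43700 nM, the first value that is a number and not a limit. Replacing methoxy with hydroxy gives an at least 1.1-fold lower number from compound 2 to compound 3 (0.05 log units; that floor lies within the scatter), so this change at the oxygen on the aromatic ring is not shown to move the read-out beyond the scatter. The step that adds trifluoromethyl cannot be read, as compound 1 holds only a limit: the limit of > 32500 nM in this assay, at which 1 of the 3 values shown sits.

Still open, from the compounds shown here alone, is what an amine or a longer alkoxy chain in place of the hydroxy group would give.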